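The source may report more compounds than this note shows. Statements on the series, on what has been measured and on what is new or still open speak of the compounds shown alone.

Measured compounds:
compound 1, `COc1cccc2c1c(C(=O)/C=C(\O)C(=O)O)cn2Cc1ccc(F)cc1`, 41100 nM
compound 2, `COc1cc2c(C(=O)/C=C(\O)C(=O)O)cn(Cc3ccc(F)cc3)c2cc1OC`, 65500 nM

In an ADME assay on MT4 cells (Homo sapiens) for cytotoxicity, read by MTT assay (a higher number here means that more compound is tolerated, a lower number that less compound is tolerated), compound 2 gives 65500 nM and compound 1 gives 41100 nM; the two numbers lie within the scatter of each other, so no difference between them can be claimed from these two measurements alone.

Compound 3, `CCOC(=O)/C(O)=C/C(=O)c1cn(Cc2ccc(F)cc2)c2cc(OC)c(OC)cc12`, has not yet been run in this assay. It departs from compound 2 by one change: ethyl in place of hydrogen on an oxygen next to a carbonyl group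

Among the measured compounds shown here, no step between two measured compounds bears on this change, since the two measured compounds differ elsewhere. Expectation therefore rests on the change itself, as counted: a small group enters on the oxygen. A shift within the scatter, or a modest move towards a lower number, is expected in this assay. Compound 3 is estimated at 40000 nM, in the range 15000 nM to 100000 nM, which means an expected step of a 1.6-fold lower number from compound 2 to compound 3 (0.21 log units; within the scatter).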

Compound 3, half-maximal cytotoxic concentration: 21800 nM
Compound 3: middle estimate off by 1.8-fold (0.26 log units), on the high side; measured number inside the range.
By their numbers in this assay, from the lowest: compounds 3, 1 and 2 (each within the scatter of the next, the first and the last beyond it).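

Carboxy to ethoxycarbonyl is the first single change in the series that can be read on its own, and in this assay it gives a 3.0-fold lower number from compound 2 to compound 3 (0.48 log units; beyond the scatter), a modest step beyond the scatter. This position therefore bears on the read-out: ethyl in place of hydrogen on the oxygen next to a carbonyl group moves the number towards less compound tolerated. Compound 1 and compound 2 differ elsewhere and showed nothing about this site, and no measurement at hand accounts for the step.

A single pair cannot separate the effect of adding ethyl from that of losing the hydrogen; a methyl group or a longer chain on this oxygen, or an amide in place of the ethoxycarbonyl, would help to do so. Going by these compounds, whether the same change gives a similar step on the core of compound 1 also remains open.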